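This account rests on a few compounds, and the source may have more. Where it says the series, first, only, none or still open, it means among the compounds named here.

Measured so far:
compound 1, `COc1ccc(NS(=O)(=O)c2ccc(N3CCNC3=O)cc2)cc1`, 580 nM
compound 2, `O=C1NCCN1c1ccc(S(=O)(=O)Nc2ccc(OC(F)F)cc2)cc1`, 410 nM
compound 3, `CCCCOc1ccc(NS(=O)(=O)c2ccc(N3CCNC3=O)cc2)cc1`, 580 nM

All three numbers come from a functional assay on M21 cells (Homo sapiens) for antiproliferative activity, read by sulforhodamine B assay, with a stated time of 48 h; a lower number here means a stronger inhibitor, a higher number a weaker inhibitor. Compound 1 gives 580 nM there and stands level with compound 3 at the digits shown, the two together holding the highest of the three numbers; compound 2 is the furthest from compound 1, by a 1.4-fold lower number from compound 1 to compound 2 (0.15 log units; within the scatter). The steps that separate the measured compounds all vary the group on the oxygen on the aromatic ring: a 1.4-fold lower number from compound 1 to compound 2 (0.15 log units; within the scatter), no change at the digits printed from compound 1 to compound 3 (within the scatter), a 1.4-fold higher number from compound 2 to compound 3 (0.15 log units; within the scatter), each within the scatter.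

Compound 4, `Cc1ccc(NS(=O)(=O)c2ccc(N3CCNC3=O)cc2)c(C)c1`, is not yet measured. It differs from compound 1 thus: 2,4-dimethylphenyl in place of 4-methoxyphenyl on a sulfonamide nitrogen. For the measured compounds named here, no measured step bears directly on this change: the oxygen on the aromatic ring is kept in every measured compound, and none carries a second substituent on that ring. The three steps do show that moving from methyl through difluoromethyl to butyl on that oxygen left this assay flat. From the compounds shown here alone, the nearest guidance is therefore that the ring on the sulfonamide nitrogen has so far accepted change without a step beyond the scatter, but removal of the oxygen itself is untested, so the range is set wide. The step from compound 1 to compound 4 is expected to be a 1.0-fold higher number from compound 1 to compound 4 (0.01 log units; within the scatter), with no direction favoured. Compound 4 is estimated at 600 nM in this assay, within 250 nM to 1500 nM.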

Compound 4, half-maximal inhibitory concentration: 150 nM
Compound 4: middle estimate off by 4.0-fold (0.60 log units), on the high side, outside the stated range (below it).
By their numbers in this assay, from the lowest: compound 4; then compounds 2, 1 and 3 (each within the scatter of the next).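

In this assay, for the compounds shown here, replacing 4-methoxyphenyl with 2,4-dimethylphenyl on a sulfonamide nitrogen gives a 3.9-fold lower number from compound 1 to compound 4 (0.59 log units; beyond the scatter), the first step beyond the scatter, whereas changing only the group on the oxygen gave a 1.4-fold lower number from compound 1 to compound 2 (0.15 log units; within the scatter) and no change at the digits printed from compound 1 to compound 3 (within the scatter). The aryl group on this nitrogen can therefore shift the number when its ring substituents are replaced, not merely when the group on the oxygen is varied, but this single change removes the methoxy group and brings in two methyl groups at once, so the step cannot be assigned to either part alone. No measurement shown accounts for the step, and its cause remains unestablished.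

The compounds shown leave open whether a ring carrying a single methyl group would retain the step, and how a chloro or amino group in place of the methyl groups would read in this assay. They also leave open whether the step from compound 1 to compound 4 would carry over to other changes made on the shared core.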